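The source may report more compounds than this note shows. Statements on the series, on what has been measured and on what is new or still open speak of the compounds shown alone.

In an ADME assay (liver) for metabolic stability, with Liver microsome (Rattus norvegicus) as the target, using microsomes and NADPH, with a stated time of 30 min, at 37 degrees C, tested at 1 uM (a lower number here means slower removal, a higher number faster removal of the compound), compound 1 `Nc1ccc(S(=O)(=O)c2ccc(-c3ccc(C(O)(C(F)(F)F)C(F)(F)F)cn3)cc2)cn1` reports only a limit of the assay, < 14 mL.min-1.g-1. Compound 2 `N#Cc1cc(C(O)(C(F)(F)F)C(F)(F)F)cnc1-c1ccc(S(=O)(=O)c2ccc(N)nc2)cc1` gives 27 mL.min-1.g-1 and compound 3 `CC(O)(c1ccc(-c2ccc(S(=O)(=O)c3ccc(N)nc3)nc2NC2CC2)nc1)C(F)(F)F` gives 43 mL.min-1.g-1, two values within the scatter of each other. Compound 4 `CC(O)(c1ccc(-c2ccc(S(=O)(=O)c3ccc(N)nc3)nc2Nc2ccccn2)nc1)C(F)(F)F` carries pyridin-2-yl in place of cyclopropyl on a nitrogen on an aromatic ring. Going by the values given here, no measured step touches that nitrogen. The only one, an at least 1.9-fold higher number from compound 1 to compound 2 (0.28 log units; that floor lies within the scatter), is cyano in place of hydrogen on an aromatic carbon, a different change that sets no size here. The expectation therefore rests on compound 3 at 43 mL.min-1.g-1, with no step beyond the scatter expected in this assay. The estimated step is a 1.2-fold higher number from compound 3 to compound 4 (0.07 log units; within the scatter). For compound 4 the estimate is 50 mL.min-1.g-1, with an expected range from 20 mL.min-1.g-1 to 120 mL.min-1.g-1.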

Compound 4, intrinsic clearance in microsomes: 130 mL.min-1.g-1
The estimate for compound 4 lay 2.6-fold (0.41 log units) below the measured number, outside the stated range (above it).
By their numbers in this assay, from the lowest: compounds 2 and 3 (each within the scatter of the next); then compound 4. At a limit, below all of these: compound 1.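

In this assay, the group on this nitrogen clearly affects the read-out: pyridin-2-yl in place of cyclopropyl gives a 3.0-fold higher number from compound 3 to compound 4 (0.48 log units; beyond the scatter). This is the only step at this nitrogen and the only step shown that lies beyond the scatter. No measurement shown bears on what lies behind the rise.

As far as these compounds go, it remains open whether the rise follows the ring nitrogen of pyridin-2-yl or the aromatic ring as a whole, which phenyl on the same nitrogen could separate. From the compounds shown here alone, the behaviour of an open chain such as ethyl at this position is also open.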